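Cytotoxicity series: cyanoethyl in place of isopropyl

The source may hold more compounds than are shown below. What is called first, only, known or untested is meant among the compounds shown, and "the series" means these compounds.

Measured so far:
compound 1, `CO/N=c1\[nH]cnc2c1[n+](Cc1ccccc1)cn2C`: > 80000 nM (a limit)
compound 2, `CO/N=c1\[nH]cnc2c1[n+](C/C=C(\C)CC/C=C(\C)CC/C=C(\C)CCC=C(C)C)cn2C(C)C`: 886 nM

In a functional assay on cells (Homo sapiens) for cytotoxicity (a lower number here means a stronger inhibitor, a higher number a weaker inhibitor), compound 1 reaches only a limit, > 80000 nM; this is the limit of > 80000 nM in this assay, at which 1 of the 2 values shown sits. In this assay, among the measured compounds shown here, compound 2 gives 886 nM, the only number so far. For the measured compounds named here, no pair of measured compounds differs in a single place, so no measured step is available.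

Compound 3, `CO/N=c1\[nH]cnc2c1[n+](C/C=C(\C)CC/C=C(\C)CC/C=C(\C)CCC=C(C)C)cn2CCC#N`, differs from compound 2 by 2-cyanoethyl in place of isopropyl on an aromatic nitrogen, the long chain on the other ring nitrogen being kept. Going by the values given here, with no measured step to lean on, the expectation for this exchange is a change of no more than the usual scatter, in neither direction with confidence. The expected step is a 1.0-fold higher number from compound 2 to compound 3 (0.01 log units; within the scatter). For compound 3 in this assay the estimate is 900 nM, with a range from 300 nM to 3000 nM.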

Compound 3, half-maximal inhibitory concentration: 3960 nM
Compound 3: the middle estimate sits 4.4-fold (0.64 log units) below what was measured; the measured number lies above the stated range.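

In this assay, among the compounds shown here, this is the first step that changes a single place, and it shows that the aromatic nitrogen does not tolerate every exchange without a shift: 2-cyanoethyl in place of isopropyl, with the long chain kept, gives a 4.5-fold higher number from compound 2 to compound 3 (0.65 log units; beyond the scatter). The step lies beyond the scatter, and compound 3 still gives a measured number, 3960 nM, rather than a limit. Nothing in the data shown gives a reason for this step.

A single exchange cannot separate the nitrile from the added length of the group; an unbranched propyl or a 2-hydroxyethyl on the same nitrogen would bear on that. Going by these compounds, whether the step carries over to a benzyl on the other ring nitrogen also stays open, as compound 1 differs from compound 2 and compound 3 in more than one place.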